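The compounds below may be only part of what the source reports. "The series", "measured", "known", "first", "only" and "open" are said of these compounds alone.

Measured compounds:
Compound 1, `C[C@@H](O)CNc1cc(Oc2ccc(NC(=O)Nc3cccc(C(F)(F)F)c3)cc2)ncn1`, gives 63 nM in an assay on isolated protein for inhibition of serine/threonine-protein kinase TNNI3K (Homo sapiens); a lower number here means a stronger inhibitor, a higher number a weaker inhibitor.
Compound 2, `Nc1cc(Oc2ccc(NC(=O)Nc3cccc(C(F)(F)F)c3)cc2)ncn1`, gives 25 nM in this assay.
Compound 3, `CNc1nccc(Oc2ccc(NC(=O)Nc3cccc(C(F)(F)F)c3)cc2)n1`, gives 50 nM in this assay.

On these numbers compound 3 gives the second highest of the three, and its distances to both neighbours are small: the gap to compound 1 and the gap to compound 2 each lie within the scatter, so no order among the three can be claimed. Compound 4, `CCNc1cc(Oc2ccc(NC(=O)Nc3cccc(C(F)(F)F)c3)cc2)ncn1`, has not been measured. It differs from compound 3 in one place: 6-(ethylamino)pyrimidin-4-yl in place of 2-(methylamino)pyrimidin-4-yl on an oxygen on an aromatic ring.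

Among the measured compounds shown here, two measured steps bear on this change. Removing the substituent on the ring nitrogen, a 2.5-fold lower number from compound 1 to compound 2 (0.40 log units; beyond the scatter), gave a modest gain; moving and methylating the amine, a 2.0-fold higher number from compound 2 to compound 3 (0.30 log units; within the scatter), stayed within the scatter. Compound 4 carries a small ethylamino group on the same position as the 2-hydroxypropyl of compound 1 and the amino of compound 2, so it is expected to land between those two and close to compound 3, with a 1.3-fold lower number from compound 3 to compound 4 (0.10 log units; within the scatter) expected to stay within the scatter. Compound 4 is therefore estimated at 40 nM, in the range 15 nM to 110 nM.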

Compound 4, half-maximal inhibitory concentration: 25 nM
The estimate for compound 4 lay 1.6-fold (0.20 log units) above the measured number; the measured number falls inside the stated range.
By their numbers in this assay, from the lowest: compounds 2, 4, 3 and 1 (each within the scatter of the next, the first and the last beyond it).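

In this assay, ethyl on the ring's amino nitrogen gives no change at the digits printed from compound 2 to compound 4 (within the scatter), so this small chain is tolerated at this position without a change beyond the scatter. The step of a 2.5-fold lower number from compound 1 to compound 4 (0.40 log units; beyond the scatter), which is modest but beyond the scatter, shows that the higher number of compound 1 goes with the 2-hydroxypropyl group and not with every substituent on this nitrogen. The exchange of 2-(methylamino)pyrimidin-4-yl for 6-(ethylamino)pyrimidin-4-yl, a 2.0-fold lower number from compound 3 to compound 4 (0.30 log units; within the scatter), stays within the scatter, so these two groups cannot be told apart on this read-out.

Nothing available explains why the 2-hydroxypropyl group differs from ethyl. As far as these compounds go, it remains open how far the chain on this nitrogen can grow, whether a propyl or butyl chain behaves like ethyl, and whether a 2-hydroxyethyl group or a morpholine would follow compound 1 or compound 4.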